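The source may hold more compounds than are shown below. What is called first, only, known or untested is meant among the compounds shown, and "the series" means these compounds.

The measured compounds:

Compound 1, `COCCOCCOCCOCCOCCOCCOCCOCCOCCOCCOC(=O)Oc1c(C(C)C)cccc1C(C)C`, gives 400000 nM
Compound 2, `COCCOCCOCCOCCOCCOCCOCCOC(=O)Oc1c(C(C)C)cccc1C(C)C`, gives 500000 nM
Compound 3, `COCCOCCOCCOCCOCCOCCOCCOCCOCCOCCOCC(=O)Oc1c(C(C)C)cccc1C(C)C`, gives 600000 nM

All three numbers come from an ADME assay on A549 cells (Homo sapiens) for cytotoxicity, read by MTT assay, with a stated time of 24 h; a higher number here means that more compound is needed for the effect, a lower number that less compound is needed. The three compounds carry the same aromatic ester end and differ only in the length of the chain of ether links attached to it. Compound 1 and compound 2 differ in one place: hydrogen in place of (2-(2-methoxyethoxy)ethoxy)methyl on a saturated chain carbon bound to an oxygen on a saturated carbon. That change produced a 1.3-fold higher number from compound 1 to compound 2 (0.10 log units; within the scatter), so the shorter chain and the longer chain gave numbers that cannot be told apart.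

Compound 4, `COCCOCCOCCOCCOCCOCCOCCOCC(=O)Oc1c(C(C)C)cccc1C(C)C`, has not been measured. It differs from compound 3 in exactly the same way: hydrogen in place of (2-(2-methoxyethoxy)ethoxy)methyl on a saturated chain carbon bound to an oxygen on a saturated carbon. The difference between the core of compound 3 and the core of compound 1 is not broken down here. Compound 3 itself gives a number that lies within the scatter of both compound 2 and compound 1, so nothing separates the three measured compounds in this assay.

For compound 4 the expectation rests on a single earlier example: the same change from compound 1 to compound 2 gave a 1.3-fold higher number from compound 1 to compound 2 (0.10 log units; within the scatter), and a step of similar size is expected here, namely a 1.2-fold higher number from compound 3 to compound 4 (0.07 log units; within the scatter). Compound 4 is therefore expected to give 700000 nM, with a likely range from 350000 nM to 1400000 nM.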

Compound 4, half-maximal effective concentration: 520000 nM
Compound 4: the middle estimate sits 1.3-fold (0.13 log units) above what was measured; measured number inside the range.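

In this assay, putting hydrogen in place of (2-(2-methoxyethoxy)ethoxy)methyl gave a 1.2-fold lower number from compound 3 to compound 4 (0.06 log units; within the scatter), so the two numbers in this pair cannot be told apart, just as those in the earlier pair could not. Set side by side, the two steps point in opposite directions on paper, but their gap is too small to count as a real difference between the cores: the same change on two cores in this assay, a 1.3-fold higher number (0.10 log units; within the scatter) from compound 1 to compound 2 and a 1.2-fold lower number (0.06 log units; within the scatter) from compound 3 to compound 4, 1.4-fold (0.16 log units) apart, within the scatter of two such steps. For the compounds shown here, this shows that, on both cores, removing this stretch of the chain produced no step that can be read in this assay; it does not show that the change has the same true effect on both, and it says nothing about how the change would behave on a core where it produced a larger step.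

The compounds shown leave open whether a much shorter chain, or a chain ending in an amine or a carboxylic acid rather than a methoxy group, would move the number beyond the scatter. Since all of them share the same aromatic ester end, they also leave open what an amide link in place of the ester would do.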